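The source may report more compounds than this note shows. Statements on the series, on what has been measured and on what is new or still open speak of the compounds shown alone.

Compound 1, `O=C(/C=C1\CCc2ccccc21)NC1CC1`, was tested in a functional assay on the whole organism with Mus musculus as the target (a higher number here means that more compound is needed for the effect, a lower number that less compound is needed), where compound 1 gives 150 mg/kg. Compound 2, `O=C(/C=C1\CCc2cc(F)ccc21)NC1CC1`, differs from compound 1 in one place fluoro in place of hydrogen on an aromatic carbon and in this assay compound 2 gives 81 mg/kg, a change of a 1.9-fold lower number from compound 1 to compound 2 (0.27 log units; within the scatter). Compound 3, `NC(=O)/C=C1\CCc2cc(F)ccc21`, has hydrogen in place of cyclopropyl on the amide-type nitrogen, and in this assay compound 3 gives 56 mg/kg, a change of a 1.4-fold lower number from compound 2 to compound 3 (0.16 log units; within the scatter). Compound 4, `NC(=O)/C=C1\CCc2c1ccc(F)c2F`, is not yet measured; it differs from compound 3 in one place (fluoro in place of hydrogen on an aromatic carbon), the same kind of change as that from compound 1 to compound 2, though here the entering fluoro sits ortho to a fluoro group and ortho to a fused ring rather than para to a fused ring. How the core of compound 1 differs from the core of compound 3 is not broken down here. The step expected here is a 1.2-fold lower number from compound 3 to compound 4 (0.09 log units; within the scatter), because the earlier step of this kind was a 1.9-fold lower number from compound 1 to compound 2 (0.27 log units; within the scatter). For compound 4 the expected dose is therefore 45 mg/kg, likely between 20 mg/kg and 110 mg/kg.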

Compound 4, dose for half-maximal effect: 45 mg/kg
Compound 4: middle estimate and measured number agree at the digits printed, within the range that was stated.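

In this assay, fluoro in place of hydrogen on an aromatic carbon gives a 1.2-fold lower number from compound 3 to compound 4 (0.09 log units; within the scatter), so this pair cannot be told apart by this measurement. Set beside the earlier step, the same change reads alike on the two cores: the same change on two cores in this assay, a 1.9-fold lower number (0.27 log units; within the scatter) from compound 1 to compound 2 and a 1.2-fold lower number (0.09 log units; within the scatter) from compound 3 to compound 4, 1.5-fold (0.17 log units) apart, within the scatter of two such steps. Among the compounds shown here, this shows only that the two steps cannot be separated; both are small, the fluoro enters at a different place in each pair, and two pairs give no general rule for other cores.

The compounds shown leave open whether chloro, methoxy or an amine on this aromatic carbon would give a step beyond the scatter. They also leave open how a longer chain on the amide nitrogen would read on the core of compound 4.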